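Chain extension on the shared core: compound 2 to compound 3

The source may hold more compounds than are shown below. What is called first, only, known or untested is meant among the compounds shown, and "the series" means these compounds.

In a functional assay on CCRF-CEM cells (Homo sapiens) for cytotoxicity (on this read-out higher numbers stand for lower toxicity in this test and lower numbers for higher toxicity in this test), compound 1 (`CC(=O)Nc1nc(N)nc2c1ncn2[C@H]1CO[C@@H](CO)O1`) gives > 100000 nM as a limit of the assay. Compound 2 (`CCCCCCCC(=O)Nc1nc(N)nc2c1ncn2[C@H]1CO[C@@H](CO)O1`) gives > 100000 nM as a limit too, so it has no number, and both compounds sit at the same limit (the limit of > 100000 nM in this assay, at which 2 of the 2 values shown sit). Compound 3 (`CCCCCCCCCCCC(=O)Nc1nc(N)nc2c1ncn2[C@H]1CO[C@@H](CO)O1`) follows from compound 2 through one change (butyl in place of hydrogen on a saturated chain carbon, seven bonds along the chain from a carbonyl carbon) in which butyl replaces hydrogen on a saturated chain carbon, seven bonds along the chain from a carbonyl carbon. Among the compounds with values here, the only measured step that bears on this is the earlier chain change (a step that the two limits leave unreadable from compound 1 to compound 2) and its size cannot be read. No step beyond the scatter is therefore expected, with any shift more likely toward lower numbers. The estimated step (an at least 1.2-fold lower number from compound 2 to compound 3 (0.09 log units; that floor lies within the scatter)) is expected to be small. In this assay the expected value for compound 3 is 80000 nM within an estimated range of 25000 nM to 100000 nM and a report of only a limit remains likely.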

Compound 3, half-maximal cytotoxic concentration: 13000 nM
The estimate for compound 3 lay 6.2-fold (0.79 log units) above the measured number; measured number below the stated range.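

In this assay, within the data shown here, butyl in place of hydrogen on a saturated chain carbon, seven bonds along the chain from a carbonyl carbon, gives the first readable change: an at least 7.6-fold lower number from compound 2 to compound 3 (0.88 log units; beyond the scatter). The full chain extension gives an at least 7.6-fold lower number from compound 1 to compound 3 (0.88 log units; beyond the scatter), so this position tolerates a chain extension that registers as higher toxicity in this test. Compound 1 and compound 2 each give only a limit of the assay, and the step between them cannot be read: the limit of > 100000 nM in this assay, at which 2 of the 3 values shown sit.

As far as these compounds go, both readable steps start from a limit, so their true size remains open. From the compounds shown here alone, it is also open whether a longer chain would lower the number further, and whether a carboxylic acid at the chain end would keep the shift seen with compound 3.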